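Formyl addition on the shared core: cytotoxicity working notes

The compounds below may be only part of what the source reports. "The series", "measured", "known", "first", "only" and "open" are said of these compounds alone.

compound 1 `O=c1oc2ccccc2cc1-c1cn2nc(Cc3ccc(Cl)cc3)sc2n1`: > 10000 nM
compound 2 `O=Cc1c(-c2ccc(F)cc2)nc2sc(Cc3ccc(Cl)cc3)nn12`: 17000 nM

In an ADME assay on CCRF-CEM cells (Homo sapiens) for cytotoxicity, with a stated time of 72 h (on this read-out lower numbers stand for stronger inhibition and higher numbers for weaker inhibition), compound 1 gives only a limit, > 10000 nM. It is one of the values sitting at the limit of > 10000 nM in this assay, at which 1 of the 2 values shown sits. Compound 2 gives 17000 nM in this assay. Compound 3 `O=Cc1c(-c2cc3ccccc3oc2=O)nc2sc(Cc3ccc(Cl)cc3)nn12` differs from compound 1 by formyl in place of hydrogen on an aromatic carbon. For the measured compounds named here, no step between measured compounds is available. The step that the limit leaves unreadable from compound 1 to compound 3 is expected to be none beyond the scatter, since compound 2 carrying the same formyl gives 17000 nM. Compound 3 is expected to give 15000 nM, in the range 5000 nM to 40000 nM.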

Compound 3, half-maximal inhibitory concentration: 750 nM
Beside the measured number, compound 3's estimate is 20-fold (1.30 log units) above it; measured number outside the range, below it.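

For the compounds shown here, on the aromatic carbon of the five-membered aromatic ring with 2 nitrogen, formyl in place of hydrogen gives an at least 13-fold lower number from compound 1 to compound 3 (1.12 log units; beyond the scatter) in this assay, the first readable step at this position and one beyond the scatter. Compound 1 gives > 10000 nM, which is a limit. The step is therefore a bound and not an exact size, because compound 1 stands at that limit: the limit of > 10000 nM in this assay, at which 1 of the 3 values shown sits.

As far as these compounds go, it remains open whether the step belongs to formyl itself or would also appear with a carboxylic acid, a nitrile or an amine on this carbon.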